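The compounds below may be only part of what the source reports. "The series", "measured", "known", "first", "only" and "open" are said of these compounds alone.

Measured so far in a functional assay on MCF7 cells (Homo sapiens) for antiproliferative activity, read by MTT assay, with stated times of 24 h and 72 h; on this read-out higher numbers stand for weaker inhibition and lower numbers for stronger inhibition:

- compound 1 `COc1cc(N2C(=O)[C@@H](Oc3ccccc3)[C@H]2c2ccc(C#N)cc2)cc(OC)c1OC` – 31600 nM
- compound 2 `COc1cc(N2C(=O)[C@@H](Oc3ccccc3)[C@H]2c2ccc(N=[N+]=[N-])cc2)cc(OC)c1OC` – 23000 nM

Among the measured compounds shown here, compound 2 stands level with compound 1, the only other measured compound, since the two values lie within the scatter of each other. For the measured compounds named here, the single measured step, a 1.4-fold lower number from compound 1 to compound 2 (0.14 log units; within the scatter), exchanged cyano for azido on an aromatic carbon and stayed within the scatter.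

The next compound, compound 3 `CCOC(=O)/C=C/c1ccc([C@@H]2[C@H](Oc3ccccc3)C(=O)N2c2cc(OC)c(OC)c(OC)c2)cc1`, carries 2-(ethoxycarbonyl)ethenyl in place of azido on an aromatic carbon, para to a large group: 2-(ethoxycarbonyl)ethenyl in place of azido on an aromatic carbon. Going by the values given here, the one measured step bears on this change only loosely, as it concerns the same kind of exchange but not this group. Among the compounds with values here, no measured compound carries 2-(ethoxycarbonyl)ethenyl, so the data offer no direct guide to its effect. Within the data shown here, with only that small step to go on, no change beyond the scatter is expected in this assay, although the uncertainty is wide in both directions.

The expected change is a 1.2-fold lower number from compound 2 to compound 3 (0.06 log units; within the scatter).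

For compound 3 the estimate is 20000 nM, with an expected range from 6000 nM to 60000 nM.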

Compound 3, half-maximal inhibitory concentration: 87000 nM
Beside the measured number, compound 3's estimate is 4.4-fold (0.64 log units) below it, and the stated range ends below it.
By their numbers in this assay, from the lowest: compounds 2 and 1 (each within the scatter of the next); then compound 3.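

Among the compounds shown here, at this place, on an aromatic carbon para to a large group, 2-(ethoxycarbonyl)ethenyl gives the first change beyond the scatter in this assay, with a 3.8-fold higher number from compound 2 to compound 3 (0.58 log units; beyond the scatter). Measured against the nitrile, the same group gives a 2.8-fold higher number from compound 1 to compound 3 (0.44 log units; beyond the scatter), so compound 3 has the highest number of the three, whereas the exchange of cyano for azido gave only a 1.4-fold lower number from compound 1 to compound 2 (0.14 log units; within the scatter) and stayed within the scatter. Nothing available here accounts for this loss of inhibition, and the size of the step is all that can be stated.

The compounds shown cannot separate the roles of the ethyl ester, the carbon-carbon double bond and the length of the chain in this step, and a carboxylic acid in place of the ester or a saturated chain of the same length would bear directly on that. On these data alone, it also remains open whether a small group such as an amine or a methoxy group at this place would stay level with compound 2 or move the number in either direction.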